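Fluoro for hydrogen on the aryl of compound 3

The compounds below may be only part of what the source reports. "The series", "measured", "known", "first", "only" and "open" are said of these compounds alone.

Within the data shown here, compound 2 `O[C@@H](c1ccccc1)[C@H]1CO[C@H](c2ccccc2)[C@@H](C/C=C/c2ccccc2)C1` holds the smaller of the two numbers so far in a functional assay on HeLa cells (Homo sapiens) for cytotoxicity, read by WST assay, with a stated time of 48 h (a higher number here means a weaker inhibitor, a lower number a stronger inhibitor), at 6060 nM; its nearest neighbour, compound 1 `Cc1ccc(/C=C/C[C@H]2C[C@@H]([C@@H](O)c3ccccc3)CO[C@@H]2c2ccccc2)cc1C`, gives 10000 nM in this assay, and the gap a 1.7-fold lower number from compound 1 to compound 2 (0.22 log units; within the scatter) sits within the scatter, so the two cannot be told apart. Compound 3 `O[C@@H](c1ccccc1)[C@H]1CO[C@H](c2ccccc2)[C@@H](C/C=C/c2ccc(F)cc2)C1` has not yet been measured in this assay. It differs from compound 2 by fluoro in place of hydrogen on an aromatic carbon. Among the measured compounds shown here, the only measured step that bears on this, a 1.7-fold lower number from compound 1 to compound 2 (0.22 log units; within the scatter), altered the same aromatic ring, phenyl in place of 3,4-dimethylphenyl, and did not move the number beyond the scatter. One fluoro entering on that ring is a smaller alteration, and nothing measured here points in either direction. The expected step from compound 2 is therefore a 1.1-fold lower number from compound 2 to compound 3 (0.04 log units; within the scatter), with no movement beyond the scatter expected. The estimate for compound 3 in this assay is 5500 nM, with an expected range from 2500 nM to 12000 nM.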

Compound 3, half-maximal inhibitory concentration: 8340 nM
For compound 3 the middle estimate is 1.5-fold (0.18 log units) below the measured one, within the range that was stated.
By their numbers in this assay, from the lowest: compounds 2, 3 and 1 (each within the scatter of the next).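

In this assay the exchange of hydrogen for fluoro on an aromatic carbon para to a large group gives a 1.4-fold higher number from compound 2 to compound 3 (0.14 log units; within the scatter) and stays within the scatter, so phenyl and 4-fluorophenyl cannot be told apart at this end of the chain. The comparison of 3,4-dimethylphenyl with 4-fluorophenyl gives a 1.2-fold lower number from compound 1 to compound 3 (0.08 log units; within the scatter) and also stays within the scatter, which extends the earlier single pair to three aryl forms on the same 3-arylprop-2-en-1-yl chain, with all three readings indistinguishable in this assay and no aryl form separated from the others. No supporting data bear on why these three readings lie together.

The compounds shown leave open whether a group of another kind on this aryl, such as an amine or a carboxylic acid, would carry the number beyond the scatter. They also leave open how much the number depends on the parts held constant so far, namely the length of the prop-2-en-1-yl chain, where a longer chain could be set against it, and the hydroxyl-bearing benzylic carbon on the shared core.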